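Removing a chloro group from the amide aryl ring

This account rests on a few compounds, and the source may have more. Where it says the series, first, only, none or still open, it means among the compounds named here.

Measured compounds:
compound 1 `Cc1cccc(-c2noc(C3CC(=O)N(c4ccc(C)c(Cl)c4)C3)n2)c1` with 240 nM
compound 2 `Cc1ccc(N2CC(c3nc(-c4cccc(C)c4)no3)CC2=O)cc1` with 1300 nM
compound 3 `O=C1CC(c2nc(-c3cccc(F)c3)no2)CN1c1ccc(Cl)c(Cl)c1` with 3200 nM

In an in vitro functional assay on HEK293-A cells for positive allosteric modulation of metabotropic glutamate receptor 5 (Homo sapiens), read by FLIPR and calcium flux (on this read-out higher numbers stand for an effect only at larger amounts of compound and lower numbers for an effect already at smaller amounts), compound 1 gives 240 nM. Compound 2 differs by hydrogen in place of chloro on an aromatic carbon and shows a 5.4-fold higher number from compound 1 to compound 2 (0.73 log units; beyond the scatter). Compound 3 gives 3200 nM, the highest number of the three; the difference between its core and the core of compound 1 is not broken down here. Compound 4 `O=C1CC(c2nc(-c3cccc(F)c3)no2)CN1c1ccc(Cl)cc1` is not yet measured; it differs from compound 3 by hydrogen in place of chloro on an aromatic carbon. This is the same kind of change as between compound 1 and compound 2, but the place differs: in compound 1 the leaving chloro sits ortho to a methyl group, in compound 3 ortho to a chloro group. Since the earlier step was a 5.4-fold higher number from compound 1 to compound 2 (0.73 log units; beyond the scatter), the expected step here is a 3.8-fold higher number from compound 3 to compound 4 (0.57 log units; beyond the scatter). For compound 4 the estimate in this assay is 12000 nM, expected between 4000 nM and 40000 nM.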

Compound 4, half-maximal effective concentration: 630 nM
For compound 4 the middle estimate is 19-fold (1.28 log units) above the measured one, and the stated range ends above it.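

In this assay, hydrogen in place of chloro on the 3,4-dichlorophenyl group gives a 5.1-fold lower number from compound 3 to compound 4 (0.71 log units; beyond the scatter), so the change does not carry its direction from one core to the other: the same change on two cores in this assay, a 5.4-fold higher number (0.73 log units; beyond the scatter) from compound 1 to compound 2 and a 5.1-fold lower number (0.71 log units; beyond the scatter) from compound 3 to compound 4, 28-fold (1.44 log units) apart, beyond the scatter of two such steps

On these two pairs, then, the step measured on one core cannot be taken as a guide to the step on the other. The pairs do not show which difference between the two cores decides the direction, or which direction a third core would follow.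

The compounds shown leave open how a methoxy group or a nitrile at that same place would compare with chloro and hydrogen on either core.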